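Cytotoxicity in THP-1 cells: methylating the pyrazole nitrogen

A few compounds are considered here, and "the series" means these few. Any claim that something is new, unique, unknown or untested is made for them only; others in the source may bear on it.

Measured so far:
Compound 1, `N#Cc1ccc(-c2ccc3[nH]c(=O)nc(-c4ccccc4)c3c2)cc1`: in an ADME assay on THP-1 cells (Homo sapiens) for cytotoxicity, read by MTT assay, with a stated time of 72 h (a lower number here means that less compound is needed, a higher number that more compound is needed for the effect), compound 1 sits at the assay limit, > 50000 nM.
Compound 2, `O=c1nc(-c2ccccc2)c2cc(-c3cn[nH]c3)ccc2[nH]1`: in this assay compound 2 likewise sits at the assay limit, > 50000 nM.

Within the data shown here, compound 2 stands only at a limit; the one other value shown is a limit too, so nothing places it (the limit of > 50000 nM in this assay, at which 2 of the 2 values shown sit). Among the measured compounds shown here, the single step, a step that the two limits leave unreadable from compound 1 to compound 2, is therefore unreadable.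

Compound 3 is `Cn1cc(-c2ccc3[nH]c(=O)nc(-c4ccccc4)c3c2)cn1`. It differs from compound 2 by methyl in place of hydrogen on an aromatic nitrogen. For the measured compounds named here, no measured step bears on this change in a readable way, since both values shown are limits. The expectation for compound 3 in this assay is thus a value again at the assay limit, with no step beyond the scatter in either direction, a step that the limit leaves unreadable from compound 2 to compound 3. The estimate for compound 3 is 60000 nM, in the range 30000 nM to 150000 nM.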

Compound 3, half-maximal effective concentration: > 50000 nM
Compound 3 gave a limit, no number; the forecaster's own chance of this, stated with the estimate: 85%; the middle value does not contradict the limit.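

In this assay, among these compounds, compound 3 gives > 50000 nM as a limit and not a number, so no step among compound 1, compound 2 and compound 3 can be read: the limit of > 50000 nM in this assay, at which 3 of the 3 values shown sit. The compounds shown leave open whether methyl in place of hydrogen on the aromatic nitrogen changes cytotoxicity at all.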